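The source may hold more compounds than are shown below. What is called first, only, known or untested is meant among the compounds shown, and "the series" means these compounds.

Compound 1 `CCn1ccnc1-c1cc(OC)c(OC)c(OC)c1` carries an ethyl on an aromatic nitrogen of the shared core. In a functional assay on HCT-15 cells (Homo sapiens) for antiproliferative activity, read by MTT assay, with a stated time of 72 h (on this read-out lower numbers stand for stronger inhibition and higher numbers for weaker inhibition), compound 1 gives only a limit, > 100000 nM, so no number is known for it. Compound 1 thus stands at the limit of > 100000 nM in this assay, at which 1 of the 2 values shown sits. Compound 2 `COc1ccc(-n2ccnc2-c2cc(OC)c(OC)c(OC)c2)cc1[N+](=O)[O-]` carries a substituted phenyl on that aromatic nitrogen in place of the ethyl. In this assay compound 2 gives 1000 nM. Going by the values given here, no step between compound 1 and compound 2 is computed; the two values show only that compound 2 has a number where compound 1 has none.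

Compound 3 `COc1cc(-c2nccn2-c2ccc(F)cc2)cc(OC)c1OC` has not yet been measured in this assay. It differs from compound 1 by 4-fluorophenyl in place of ethyl on an aromatic nitrogen. Compound 2, with a six-membered aromatic ring on the aromatic nitrogen, gives 1000 nM in this assay, and on that ground a large step toward stronger inhibition from compound 1 to compound 3 is expected, well beyond the scatter. Compound 3 is therefore expected to give about 2000 nM in this assay, within a range from 300 nM to 20000 nM. For compound 3 this estimate means an expected step of an at least 50-fold lower number from compound 1 to compound 3 (1.69 log units; beyond the scatter).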

Compound 3, half-maximal inhibitory concentration: 68600 nM
Estimate against measurement, compound 3: 34-fold (1.54 log units) below; the measured number lies above the stated range.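

In this assay, 4-fluorophenyl in place of ethyl on this aromatic nitrogen gives an at least 1.4-fold lower number from compound 1 to compound 3 (0.16 log units; that floor lies within the scatter), so although compound 3 has a number, the data do not establish a real gain over ethyl. This step can be read only as a floor, because compound 1 has a limit and not a number: the limit of > 100000 nM in this assay, at which 1 of the 3 values shown sits. A six-membered aromatic ring on this nitrogen is therefore not enough on its own to reach the level of compound 2: compound 3 gives 68600 nM, whereas compound 2 gives 1000 nM, and these two compounds differ only in the aromatic group at this position.

The compounds shown leave open which feature of the substituted phenyl of compound 2 goes with its lower number, and by how much 4-fluorophenyl truly differs from ethyl. They also leave open how an amine or a carboxylic acid on that phenyl ring, or a longer chain in place of ethyl, would read in this assay.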